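Three sulfonyl analogues at the assay limit, a fourth awaited

The compounds below may be only part of what the source reports. "The series", "measured", "known", "first", "only" and "open" are said of these compounds alone.

Compound 1 `COc1ccc(-c2cc(=O)c3c(OC)cc(OC)cc3n2S(=O)(=O)c2ccc(C)c([N+](=O)[O-])c2)cc1` gives > 51700 nM in a functional assay on KOPN-8 cells (Homo sapiens) for antiproliferative activity, with a stated time of 72 h; on this read-out higher numbers stand for an effect only at larger amounts of compound and lower numbers for an effect already at smaller amounts; this is a limit.
Compound 2 `COc1ccc(-c2cc(=O)c3c(OC)cc(OC)cc3n2S(=O)(=O)c2c(F)c(F)c(F)c(F)c2F)cc1` gives > 34400 nM in this assay; this is a limit.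
Compound 3 `COc1ccc(-c2cc(=O)c3c(OC)cc(OC)cc3n2S(=O)(=O)c2ccc(Cl)cc2)cc1` gives > 34400 nM in this assay; this is a limit.

Compound 3 thus sits at the limit shared by two of the three values, as the limit of > 34400 nM in this assay, at which 2 of the 3 values shown sit, shows, while the limit of > 51700 nM in this assay, at which 1 of the 3 values shown sits, holds the third. The steps a step that the two limits leave unreadable from compound 1 to compound 2, a step that the two limits leave unreadable from compound 1 to compound 3 and a step that the two limits leave unreadable from compound 2 to compound 3 are all unreadable, so none of the changes on the sulfonyl sulfur has yet yielded a number. Compound 4 `COc1ccc(-c2cc(=O)c3c(OC)cc(OC)cc3n2S(=O)(=O)c2cc(Cl)cc(Cl)c2O)cc1` differs from compound 3 by 3,5-dichloro-2-hydroxyphenyl in place of 4-chlorophenyl on a sulfonyl sulfur. Among the compounds with values here, no measured step bears on this change, so a step that the limit leaves unreadable from compound 3 to compound 4 is expected in this assay, most likely again ending at a limit. Compound 4 is therefore estimated at 40000 nM, between 10000 nM and 100000 nM.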

Compound 4, half-maximal effective concentration: > 37900 nM
Compound 4: a limit, no number; the forecaster's own chance of this, stated with the estimate: 70%; the middle value is on the limit's open side.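

Compound 4 also ends at a limit, as do compound 1, compound 2 and compound 3, so no step among these four can be read. On these data alone, what a change on the sulfonyl sulfur does to the read-out in this assay stays open.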